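The source may hold more compounds than are shown below. What is called first, only, known or untested is meant among the compounds shown, and "the series" means these compounds.

Of the compounds shown here, three of the shared core have been measured. Compound 3 `[O-][S+](Cc1ccc(Cl)s1)C(c1ccccc1)c1ccccc1` gives 12800 nM in an assay on HEK293 cells for inhibition of sodium-dependent dopamine transporter (Homo sapiens), read by scintillation counting, with stated times of 5 min and 1 min (a higher number here means a weaker inhibitor, a lower number a stronger inhibitor), the second highest of the three numbers. Compound 1 `[O-][S+](Cc1cc(Br)cs1)C(c1ccccc1)c1ccccc1` gives 13700 nM in this assay, and the step of a 1.1-fold lower number from compound 1 to compound 3 (0.03 log units; within the scatter) lies within the scatter. Compound 2 `Cc1ccc(C(c2ccc(C)cc2)[S+]([O-])Cc2cccs2)cc1` differs from compound 3 in two places. In this assay compound 2 gives 5800 nM, and the two values alone show compound 2 with the lower number of the pair, beyond the scatter.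

The step to compound 4 `[O-][S+](Cc1cc(C2CC2)on1)C(c1ccccc1)c1ccccc1` is 5-cyclopropyl-1,2-oxazol-3-yl in place of 5-chlorothiophen-2-yl on a saturated chain carbon bound to a sulfur. Within the data shown here, the only measured step on a single change, a 1.1-fold lower number from compound 1 to compound 3 (0.03 log units; within the scatter), exchanges 4-bromothiophen-2-yl for 5-chlorothiophen-2-yl and hardly moves the number; it bears on the present change only loosely, since here the whole ring together with its substituent is exchanged. Among the measured compounds shown here, no measured pair shows 5-chlorothiophen-2-yl replaced by 5-cyclopropyl-1,2-oxazol-3-yl, so there is no direct guide. Because compound 3 gives 12800 nM and compound 1 gives 13700 nM in this assay, compound 4 is expected to stay near those numbers, with the change a 1.3-fold lower number from compound 3 to compound 4 (0.11 log units; within the scatter) estimated as small and uncertain in direction. Compound 4 is therefore estimated at 10000 nM, within a range from 3000 nM to 40000 nM.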

Compound 4, half-maximal inhibitory concentration: 38600 nM
Beside the measured number, compound 4's estimate is 3.9-fold (0.59 log units) below it; the measured number falls inside the stated range.
By their numbers in this assay, from the lowest: compound 2; then compounds 3 and 1 (each within the scatter of the next); then compound 4.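

The new step shows that this place on a saturated chain carbon bound to a sulfur is not indifferent to the group it carries. Among these compounds, the two halogenated thiophene groups of the earlier compounds gave numbers within the scatter of each other, whereas 5-cyclopropyl-1,2-oxazol-3-yl gives a weaker inhibitor in this assay, with a 3.0-fold higher number from compound 3 to compound 4 (0.48 log units; beyond the scatter) and, against the other thiophene group, a 2.8-fold higher number from compound 1 to compound 4 (0.45 log units; beyond the scatter). Both steps lie beyond the scatter and point the same way, but nothing available explains the rise in the number.

The exchange replaces the ring and its substituent together, so these compounds cannot separate the share of the five-membered aromatic ring with 2 hetero atoms from that of the cyclopropyl ring. As far as these compounds go, it also remains open whether an amine or a carboxylic acid in place of the cyclopropyl ring would bring the number back towards those of the thiophene compounds, or raise it further.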